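The source may report more compounds than this note shows. Statements on the series, on what has been measured and on what is new or still open speak of the compounds shown alone.

Of the compounds shown here, three sharing one core have been tested in a functional assay on the whole organism for inhibition, with Rattus norvegicus as the target, at a dose of 0.3 mg/kg by the oral route; on this read-out lower numbers stand for a weaker effect and higher numbers for a stronger effect at the one dose given. Compound 1 `CCOc1cc(C(=O)Nc2nn[nH]n2)nc(-c2ccc(C)cc2)c1` gives 26%. Compound 2 `CCOc1cc(C(=O)Nc2nn[nH]n2)nc(-c2ccc(N)cc2)c1` gives 19% in this assay, and compound 3 `CCCc1ccc(-c2cc(C)cc(C(=O)Nc3nn[nH]n3)n2)cc1` gives 19%. Compound 1 stands highest of the three numbers, but its nearest neighbour, compound 2, and its furthest, compound 3, both lie within the scatter of it, so no order among the three can be read. Among the compounds with values here, the single step between two compounds that differ in one place, a number 7 percentage points lower from compound 1 to compound 2 (within the scatter), is amino in place of methyl on an aromatic carbon and stays within the scatter.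

Compound 4 `CCc1cc(C(=O)Nc2nn[nH]n2)nc(-c2ccc(C)cc2)c1` has not yet been measured in this assay. It differs from compound 1 by ethyl in place of ethoxy on an aromatic carbon. Within the data shown here, no measured step bears on this position: the one known step alters a group elsewhere in the structure, and compound 3 is not a one-place partner of compound 1, although compound 1 and compound 3 give numbers within the scatter of each other. With nothing pointing either way, compound 4 is expected to differ from compound 1 by a number 4 percentage points lower from compound 1 to compound 4 (within the scatter), a step not beyond the scatter. Compound 4 is therefore estimated at 22%, with a range from 5% to 40%.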

Compound 4, a percentage reported as inhibition, in the whole organism at one dose (the size of the read-out at that dose, not a potency): 33%
Estimate against measurement, compound 4: 11 percentage points below, and the stated range covers the measured number.
By their numbers in this assay, from the lowest: compounds 2, 3, 1 and 4 (each within the scatter of the next, the first and the last beyond it).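

The position opposite the ring nitrogen now has a measured step in this assay, and ethyl in place of ethoxy gives a number 7 percentage points higher from compound 1 to compound 4 (within the scatter). On the 4-methylphenyl compounds, then, the oxygen and the hydrogen-bond acceptor carried by ethoxy can be removed without a step beyond the scatter, so this pair gives no sign that the read-out at this one dose depends on them. Nothing available explains this outcome or separates a real effect of the exchange from ordinary scatter.

The compounds shown leave open whether a group of a different kind at this position, such as an amine, a carboxylic acid or a longer chain like butyl, would produce a step beyond the scatter. They also leave open whether ethyl in place of ethoxy would give a similar step alongside the amino group of compound 2, and whether this pair would stay within the scatter of each other at any dose other than the single one given in this assay.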